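Swapping the Aniline Group on a Shared Core

A few compounds are considered here, and "the series" means these few. Any claim that something is new, unique, unknown or untested is made for them only; others in the source may bear on it.

Compound 1 `COc1cc(Nc2ncc(C(F)(F)F)c(N3Cc4cccc(N(C)S(C)(=O)=O)c4C3)n2)c(OC)cc1Cl` gives 6200 nM
Compound 2 `Cc1cc(C)cc(Nc2ncc(C(F)(F)F)c(N3Cc4cccc(N(C)S(C)(=O)=O)c4C3)n2)c1` gives > 30000 nM

Both compounds were tested in a functional assay on U-87MG ATCC cells for antiproliferative activity against U-87 MG (Homo sapiens), read by spectrophotometry, with a stated time of 2 days (on this read-out higher numbers stand for weaker inhibition of growth and lower numbers for stronger inhibition of growth), and differ only in the group on a nitrogen. Compound 2 stands at > 30000 nM, which is a limit of the assay and not a number. The next compound, compound 3 `Cc1cc(Cl)ccc1Nc1ncc(C(F)(F)F)c(N2Cc3cccc(N(C)S(C)(=O)=O)c3C2)n1`, carries 4-chloro-2-methylphenyl in place of 3,5-dimethylphenyl on a nitrogen on an aromatic ring and keeps the rest of the structure.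

Within the data shown here, one measured step bears on this change. Replacing 4-chloro-2,5-dimethoxyphenyl with 3,5-dimethylphenyl gave an at least 4.8-fold higher number from compound 1 to compound 2 (0.68 log units; beyond the scatter), a change beyond the scatter. The entering group shares its 4-chloro with the group of compound 1 at 6200 nM, so a return part of the way towards that value seems reasonable. With one step to go on, this expectation remains loose. The expected move is an at least 2.5-fold lower number from compound 2 to compound 3 (0.39 log units; beyond the scatter), towards stronger inhibition of growth. For compound 3 the estimate is 12000 nM, with an expected range from 4000 nM to 30000 nM.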

Compound 3, concentration for 50% growth inhibition: 28300 nM
For compound 3 the middle estimate is 2.4-fold (0.37 log units) below the measured one; the range from low to high includes it.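

A 4-chloro on the group attached to the nitrogen does not suffice on its own to match the best value shown: going from 4-chloro-2,5-dimethoxyphenyl to 4-chloro-2-methylphenyl gives a 4.6-fold higher number from compound 1 to compound 3 (0.66 log units; beyond the scatter), and unlike the earlier step this one has a measured number at both ends. The other new step, from 3,5-dimethylphenyl to 4-chloro-2-methylphenyl, reads an at least 1.0-fold lower number from compound 2 to compound 3 (0.02 log units; that floor lies within the scatter), so it shows no gain that can be told from the scatter, even though the two groups differ in where their substituents sit and in the presence of chlorine. The reading for compound 2 is a limit of the assay and not a number, and the true size of this step stays unfixed because of it: the limit of > 30000 nM in this assay, at which 1 of the 3 values shown sits.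

The two groups sharing the 4-chloro differ in more than one substituent, so the compounds shown cannot tell whether the gain in compound 1 follows one methoxy group, the other, or both. As far as these compounds go, how the shared core responds to a quite different group on the same ring, such as an amine or a carboxylic acid, also remains open.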